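Replacing one fluorine by hydrogen: a small lipophilicity step

This account rests on a few compounds, and the source may have more. Where it says the series, first, only, none or still open, it means among the compounds named here.

Measured so far:
Compound 1, `OCCC(F)(F)CF`, in a physicochemical assay for lipophilicity, read by NMR (on this read-out lower numbers stand for lower lipophilicity and higher numbers for higher lipophilicity), compound 1 gives 0.27.
Compound 2, `OCCC(F)CF`, in this assay compound 2 gives -0.12.
Compound 3, `FC(F)CCOc1ccc2[nH]ccc2c1`, in this assay compound 3 gives 2.6.

Compound 1 and compound 2 are small alcohols that differ in one spot: hydrogen in place of fluoro on a saturated chain carbon bound to a fluorine atom and two saturated chain carbons. That change gave a number 0.39 log units lower from compound 1 to compound 2 (beyond the scatter), a modest drop. Compound 3 belongs to a different, much larger family; the difference between its core and the core of compound 1 is not broken down here, and in this assay compound 3 stands highest of the three measured numbers.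

Compound 4, `FCCCOc1ccc2[nH]ccc2c1`, has not yet been measured. It differs from compound 3 in this way: hydrogen in place of fluoro on a saturated chain carbon bound to a fluorine atom and a saturated chain carbon. For the measured compounds named here, this is the same kind of change as the one from compound 1 to compound 2, but not the same: in the earlier pair the carbon carrying the change is bound to a fluorine atom and two saturated chain carbons, here it is bound to a fluorine atom and only one saturated chain carbon. Read one bond further out, the change is a difluoromethyl becoming a fluoromethyl.

Because compound 1 to compound 2 gave a number 0.39 log units lower from compound 1 to compound 2 (beyond the scatter), a step of about that size is expected here too, namely a number 0.40 log units lower from compound 3 to compound 4 (beyond the scatter). For compound 4, the expected value in this assay is 2.2, with a likely range from 1.8 to 2.6. This rests on a single measured pair, so the expectation is only loosely held.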

Compound 4, partition coefficient: 2.5
Beside the measured number, compound 4's estimate is 0.30 log units below it; the measured number falls inside the stated range.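

On the larger core, putting hydrogen in place of one fluorine gave a number 0.10 log units lower from compound 3 to compound 4 (within the scatter) and the 3,3-difluoropropyl and 3-fluoropropyl compounds therefore cannot be told apart in this assay on these numbers. On the small alcohols, the related swap gave a number 0.39 log units lower from compound 1 to compound 2 (beyond the scatter) and this shows that a step beyond the scatter on one core need not reappear as one on another, so in this series the size of the change cannot simply be copied from one core to the next. It does not show that the core alone decides the size of the step: the two swaps also happen at different places, one on a saturated chain carbon bound to a fluorine atom and two saturated chain carbons, the other on a saturated chain carbon bound to a fluorine atom and a saturated chain carbon, and nothing measured here offers a reason for the contrast.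

The compounds shown leave open how the same swap would read on other cores, such as one carrying an amine or a carboxylic acid. They also leave open what happens on a longer chain, or when a trifluoromethyl group gives way to difluoromethyl.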